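The compounds below may be only part of what the source reports. "The series", "measured", "known", "first", "only" and "open" are said of these compounds alone.

Of the compounds shown here, two of a shared core have been measured. Compound 1 `COc1ccc(C(=O)N[C@H]2CCC[C@H](NC(=O)c3cccc(Cl)c3)C2)cc1` carries a 4-methoxyphenyl on one carbonyl and a 3-chlorophenyl on the other; in a functional assay on HEK293 cells for antagonist activity at metabotropic glutamate receptor 5 (Homo sapiens), read by FLIPR and calcium flux (on this read-out lower numbers stand for stronger inhibition and higher numbers for weaker inhibition), compound 1 gives 266 nM. Compound 2 `N#Cc1cccc(C(=O)N[C@@H]2CCC[C@@H](NC(=O)c3ccccn3)C2)c1` pairs a nitrile-bearing phenyl with a pyridin-2-yl on the same core, and in this assay compound 2 gives 231 nM. Of the two numbers shown, that of compound 1 is the larger, but the gap to compound 2 lies within the usual scatter, so the two cannot be told apart on this evidence.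

Compound 3 `Cc1cccnc1C(=O)N[C@H]1CCC[C@H](NC(=O)c2cccc(Cl)c2)C1` keeps the 3-chlorophenyl amide of compound 1 and changes the other amide: 3-methylpyridin-2-yl in place of 4-methoxyphenyl on a carbonyl carbon. Within the data shown here, no measured pair shows this change on its own. What can be said is that compound 2, with a pyridine on a carbonyl, gives a value close to that of compound 1, so a pyridine at this position is not expected to move the number far. The step from compound 1 to compound 3 in this assay is therefore expected to be small, a 1.2-fold lower number from compound 1 to compound 3 (0.08 log units; within the scatter), with no clear direction beyond the scatter. Compound 3 is expected to give 220 nM, within a range from 75 nM to 650 nM.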

Compound 3, half-maximal inhibitory concentration: 7840 nM
Compound 3: the middle estimate sits 36-fold (1.55 log units) below what was measured, outside the stated range (above it).
By their numbers in this assay, from the lowest: compounds 2 and 1 (each within the scatter of the next); then compound 3.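

In this assay the group on this carbonyl carbon turns out to matter a great deal: with the 3-chlorophenyl amide held fixed, 3-methylpyridin-2-yl in place of 4-methoxyphenyl gives a 29-fold higher number from compound 1 to compound 3 (1.47 log units; beyond the scatter) and so a much weaker inhibitor. Compound 2 could not show this, since it differs from compound 1 at both amides and its close value says nothing about this one change taken alone. Nothing measured here gives a reason for so large a step.

On these data alone, the swap alters two things at once, putting a nitrogen into the ring and exchanging a methoxy group for a methyl group, so it remains open which of these carries the loss, or whether only the two together do. A 3-methylphenyl group on this carbonyl carbon, paired with the same 3-chlorophenyl amide, would keep the methyl group without the ring nitrogen and would begin to pull the two apart.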